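Swapping a Sulfur Group for Ethyl on a Urea Side Ring

The compounds below may be only part of what the source reports. "The series", "measured", "known", "first", "only" and "open" are said of these compounds alone.

Three urea compounds share one core and differ only in the group on the far side ring. Compound 1 `COc1ccc(NC(=O)Nc2cc(C)nc3ccccc23)cc1` carries a methoxy there. Compound 2 `Cc1cc(NC(=O)Nc2ccc(N)cc2)c2ccccc2n1` carries an amino, and compound 3 `Cc1cc(NC(=O)Nc2ccc(SC(F)(F)F)cc2)c2ccccc2n1` a (trifluoromethyl)sulfanyl. In an ADME assay on BJ cells (Homo sapiens) for cytotoxicity, with a stated time of 72 h (on this read-out higher numbers stand for an effect only at larger amounts of compound and lower numbers for an effect already at smaller amounts), compound 1 gives > 25000 nM, which is a limit of the assay rather than a number. Compound 2 likewise reaches only the limit > 25000 nM. Compound 3 also stands at a limit, with > 25000 nM. Because all three sit at the limit of > 25000 nM in this assay, at which 3 of the 3 values shown sit, the steps a step that the two limits leave unreadable from compound 1 to compound 2, a step that the two limits leave unreadable from compound 1 to compound 3 and a step that the two limits leave unreadable from compound 2 to compound 3 have no readable size. Compound 4 `CCc1ccc(NC(=O)Nc2cc(C)nc3ccccc23)cc1` is the next member, with ethyl in place of (trifluoromethyl)sulfanyl on an aromatic carbon. For the measured compounds named here, none of the measured steps gives a readable size, so no direction can be drawn from them. In this assay the expected step is a step that the limit leaves unreadable from compound 3 to compound 4, most likely ending again at a limit. The expected value for compound 4 is estimated at 30000 nM, with a range from 15000 nM to 80000 nM.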

Compound 4, half-maximal effective concentration: > 25000 nM
Compound 4 ended at the assay's limit; the forecaster's own chance of this, stated with the estimate: 80%; the middle value does not contradict the limit.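

None of the steps from compound 1, compound 2 or compound 3 to compound 4 can be read, because all four compounds stand at the same limit: the limit of > 25000 nM in this assay, at which 4 of the 4 values shown sit.

The compounds shown leave open whether these side-ring groups differ at all in this assay, and at what amount of compound any effect would appear.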